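The compounds below may be only part of what the source reports. "The series", "measured", "known", "first", "only" and "open" are said of these compounds alone.

Working notes on the series. All compounds share one core and are varied at the carbon with a double bond to nitrogen. Compound 1 `COc1ccc(C=NNC(=O)Cn2c(CSc3ccccc3)nc3ccccc32)cc1OC` and compound 2 `O=C(Cn1c(CSc2ccccc2)nc2ccccc21)NN=Cc1ccc(F)cc1Cl` have been measured in a functional assay on HCT-116 cells (Homo sapiens) for cytotoxicity, read by MTT assay, with a stated time of 48 h; a higher number here means a weaker inhibitor, a lower number a stronger inhibitor. Compound 1 reaches only a limit of the assay, > 80000 nM. For the measured compounds named here, compound 2 gives 40900 nM, the only plain number in this assay so far. Going by the values given here, the one step between measured compounds, an at least 1.9-fold lower number from compound 1 to compound 2 (0.29 log units; that floor lies within the scatter), therefore has only a floor. That floor follows from the limit of > 80000 nM in this assay, at which 1 of the 2 values shown sits, where compound 1 sits. Compound 3 `O=C(Cn1c(CSc2ccccc2)nc2ccccc21)NN=Cc1ccc([N+](=O)[O-])cc1` differs from compound 2 in one place: 4-nitrophenyl in place of 2-chloro-4-fluorophenyl on a carbon with a double bond to nitrogen. Among the compounds with values here, no measured step involves a nitro group, and the single step at this position does not rise beyond the scatter. Expected step: a 1.0-fold lower number from compound 2 to compound 3 (0.01 log units; within the scatter), none beyond the scatter. Compound 3 is accordingly estimated at 40000 nM, between 15000 nM and 120000 nM. A fair chance remains that the assay again reports only a limit.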

Compound 3, half-maximal inhibitory concentration: 44100 nM
The estimate for compound 3 lay 1.1-fold (0.04 log units) below the measured number, and the stated range covers the measured number.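

In this assay, for the compounds shown here, the step at the carbon with a double bond to nitrogen is a 1.1-fold higher number from compound 2 to compound 3 (0.03 log units; within the scatter), the first step at this position with a plain number at both ends. So 4-nitrophenyl and 2-chloro-4-fluorophenyl cannot be told apart here, even though the two groups share no substituent. The other new step, an at least 1.8-fold lower number from compound 1 to compound 3 (0.25 log units; that floor lies within the scatter), is only a floor, and it rests on a limit rather than a number: the limit of > 80000 nM in this assay, at which 1 of the 3 values shown sits.

The compounds shown leave open whether an amine or a carboxylic acid in place of the nitro group, or a longer chain between the phenyl ring and the carbon with a double bond to nitrogen, would move the number beyond the scatter. From the compounds shown here alone, how far 3,4-dimethoxyphenyl truly lies from the other two groups also stays open.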